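This account rests on a few compounds, and the source may have more. Where it says the series, first, only, none or still open, it means among the compounds named here.

Compound 1 `CN(Cc1ccc(Cl)cc1)Cc1ccccc1CNc1ccnc2cc(Cl)ccc12` gives 9.6
Compound 2 `CN(Cc1ccc(N(C)C)cc1)Cc1ccccc1CNc1ccnc2cc(Cl)ccc12` gives 9.71

In a physicochemical assay for acid dissociation, compound 2 gives 9.71 and stands level with compound 1, the gap between them lying within the scatter. Compound 3 `COc1ccc(CN(C)Cc2ccccc2CNc2ccnc3cc(Cl)ccc23)cc1` differs from compound 2 in one place, with methoxy in place of dimethylamino on an aromatic carbon. For the measured compounds named here, the only measured step bearing on this put dimethylamino in place of chloro (a number 0.11 log units higher from compound 1 to compound 2 (within the scatter)) and stayed within the scatter, so no step beyond the scatter is expected in this assay here. The estimate therefore means only a small expected shift (a number 0.06 log units lower from compound 2 to compound 3 (within the scatter)). For compound 3 the estimated value is 9.65 (range 9.35 to 9.95).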

Compound 3, acid dissociation constant: 9.85
Compound 3: the middle estimate sits 0.20 log units below what was measured; the measured number falls inside the stated range.
By their numbers in this assay, from the lowest: compounds 1, 2 and 3 (each within the scatter of the next).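

In this assay, methoxy in place of dimethylamino on this aromatic carbon, para to a large group, gives a number 0.14 log units higher from compound 2 to compound 3 (within the scatter), and methoxy in place of chloro gives a number 0.25 log units higher from compound 1 to compound 3 (within the scatter). Chloro, dimethylamino and methoxy at this position therefore all read level with one another, so a third group now shows no step beyond the scatter. No available evidence bears on why these groups read alike. From the compounds shown here alone, whether a carboxylic acid, a primary amine or a longer alkyl chain at this position would move the number beyond the scatter remains open.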